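The source may hold more compounds than are shown below. What is called first, only, known or untested is meant among the compounds shown, and "the series" means these compounds.

Measured compounds:
compound 1 `COCc1cc(CN2CCCC2)c(O)c2ncccc12` — 52500 nM
compound 2 `CCOCc1cc(CN2CCCC2)c(O)c2ncccc12` — 33100 nM
compound 3 `CCOCc1cc(CN2CCCCC2)c(O)c2ncccc12` — 23400 nM

All three were tested in a functional assay on A-431 cells (Homo sapiens) for inhibition, with a stated time of 72 h; a lower number here means a stronger inhibitor, a higher number a weaker inhibitor. Compound 1 gives 52500 nM. Compound 2 differs by methyl in place of hydrogen on a saturated chain carbon bound to an oxygen on a saturated carbon, and the step is a 1.6-fold lower number from compound 1 to compound 2 (0.20 log units; within the scatter). Compound 3 carries piperidin-1-yl in place of pyrrolidin-1-yl, with a 1.4-fold lower number from compound 2 to compound 3 (0.15 log units; within the scatter). Compound 3 has the lowest number of the three, but only the gap to compound 1 lies beyond the scatter.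

Compound 4 `CCCOCc1cc(CN2CCCCC2)c(O)c2ncccc12` has not yet been measured. Relative to compound 3 it shows (methyl in place of hydrogen on a saturated chain carbon, two bonds along the chain from an oxygen on a saturated carbon). This is the same kind of change as that from compound 1 to compound 2, though the place differs: there the carbon was bound to the oxygen, here it lies two bonds along the chain from it. The difference between the core of compound 3 and that of compound 1 is not broken down here.

Because a 1.6-fold lower number from compound 1 to compound 2 (0.20 log units; within the scatter) stayed within the scatter, compound 4 is expected to give 18000 nM, from 8000 nM to 40000 nM. The expected step of a 1.3-fold lower number from compound 3 to compound 4 (0.11 log units; within the scatter) is accordingly modest.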

Compound 4, half-maximal inhibitory concentration: 6760 nM
The estimate for compound 4 lay 2.7-fold (0.43 log units) above the measured number; measured number outside the range, below it.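

In this assay, going from ethoxy to propoxy gives a 3.5-fold lower number from compound 3 to compound 4 (0.54 log units; beyond the scatter) and so lies beyond the scatter, while the earlier methyl for hydrogen change on the core of compound 1 stayed within it. Set side by side, the two steps cannot be told apart: the same change on two cores in this assay, a 1.6-fold lower number (0.20 log units; within the scatter) from compound 1 to compound 2 and a 3.5-fold lower number (0.54 log units; beyond the scatter) from compound 3 to compound 4, 2.2-fold (0.34 log units) apart, within the scatter of two such steps. Among the compounds shown here, this shows that the change can be carried between these two cores without a demonstrable difference in its size, but it does not show that the step is constant, since there is only one pair on each core and the place of the change differs as well as the core.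

The compounds shown leave open whether a longer chain such as butoxy would lower the number further. They also leave open how propoxy would read out with pyrrolidin-1-yl, or with an amine at the end of the chain.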